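Swapping the aryl amide in a chemokine receptor binder

The source may hold more compounds than are shown below. What is called first, only, known or untested is meant among the compounds shown, and "the series" means these compounds.

Three measured compounds share one core, and all were tested in an assay on MDA-MB-231 cells for binding affinity to C-X-C chemokine receptor type 4 (Homo sapiens), read by immunofluorescence and microscopy, with stated times of 10 min and 30 min; on this read-out lower numbers stand for an effect already at smaller amounts and higher numbers for an effect only at larger amounts of compound. Compound 1, `COc1ccc(C(=O)NCc2ccc(CNS(=O)(=O)c3ccc(C)cc3)cc2)cc1`, gives 100 nM. Compound 2, `Cc1ccccc1C(=O)NCc1ccc(CNS(=O)(=O)c2ccccc2)cc1`, gives 1 nM, and compound 3, `O=C(NCc1ccc(CNS(=O)(=O)c2ccccc2)cc1)c1c(Cl)cc(Cl)cc1Cl`, gives 10 nM. On these numbers compound 1 stands highest: compound 3 lies nearest to it, and compound 2 lies furthest away, both steps reaching beyond the scatter.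

The compound still to be measured is compound 4, `Cc1ccc(S(=O)(=O)NCc2ccc(CNC(=O)c3cccc(F)c3)cc2)cc1`. It differs from compound 1 in one place, (3-fluorophenyl in place of 4-methoxyphenyl on a carbonyl carbon), while the rest of the molecule stays as it is in compound 1.

For the measured compounds named here, only one measured step touches the same place, the aryl group on the carbonyl carbon: a 10-fold higher number from compound 2 to compound 3 (1.00 log units; beyond the scatter). That step shows the aryl group on the carbonyl can move the read-out by a modest amount, but it does not show what a 3-fluorophenyl group does, and it starts from a different pair of groups than the change from compound 1. The direction for compound 4 is therefore open, and a step of about that size in either direction would not surprise.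

Taking compound 1 as the anchor, compound 4 is expected at 50 nM, with a range from 10 nM to 300 nM, an estimated step of a 2.0-fold lower number from compound 1 to compound 4 (0.30 log units; within the scatter).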

Compound 4, effective concentration (reported as EC, without a stated level of effect): 1 nM
Estimate against measurement, compound 4: 50-fold (1.70 log units) above; measured number below the stated range.
By their numbers in this assay, from the lowest: compounds 2 and 4 (each within the scatter of the next); then compound 3; then compound 1.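

In this assay, the step from the 4-methoxyphenyl to the 3-fluorophenyl group is a 100-fold lower number from compound 1 to compound 4 (2.00 log units; beyond the scatter), while the rest of the molecule stays the same. The aryl group on the carbonyl carbon can therefore carry a large change in this series, not only the modest one seen earlier as a 10-fold higher number from compound 2 to compound 3 (1.00 log units; beyond the scatter), and this new step points towards lower numbers rather than higher ones. No measured evidence bears on why this swap has such a large effect.

The swap replaces one group with another and also moves the substituent to a different printed ring position, so the compounds shown cannot separate the contribution of the fluorine from that of its position. Placing a 4-fluorophenyl, a 3-methoxyphenyl or an unsubstituted phenyl group on the same carbonyl carbon of the core of compound 1 would help to pull these two changes apart, and a 3-chlorophenyl group would show whether fluorine itself matters.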